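Adding a second methoxy to the benzylamino series

A few compounds are considered here, and "the series" means these few. Any claim that something is new, unique, unknown or untested is made for them only; others in the source may bear on it.

Values in an ADME assay on J774.A1 cells (Mus musculus) for inhibition, read by MTT assay, with a stated time of 72 h; on this read-out lower numbers stand for an effect already at smaller amounts and higher numbers for an effect only at larger amounts of compound:
- compound 1 `CNc1nc(NCc2ccccc2)nc2ccccc12` gives 15000 nM
- compound 2 `Cc1ccc(CNc2nc(NCc3ccccc3)nc3ccccc23)cc1` gives 2100 nM
- compound 3 `COc1ccc(CNc2nc(NCc3ccccc3)nc3ccccc23)cc1` gives 5200 nM

Compound 3 holds the second highest of the three numbers. Compound 4 `COc1ccc(CNc2nc(NCc3ccc(OC)cc3)c3ccccc3n2)cc1` differs from it by methoxy in place of hydrogen on an aromatic carbon with methoxy in place of hydrogen on an aromatic carbon, turning benzyl to 4-methoxybenzyl. For the measured compounds named here, no measured step isolates this change. The closest are a 2.9-fold lower number from compound 1 to compound 3 (0.46 log units; beyond the scatter) for the whole 4-methoxyphenyl group and a 2.5-fold higher number from compound 2 to compound 3 (0.39 log units; beyond the scatter) for methoxy in place of methyl. Both are modest, and they run in opposite directions, so no step beyond the scatter is expected in this assay and no firm direction. The expected step is a 1.2-fold lower number from compound 3 to compound 4 (0.06 log units; within the scatter) in this estimate. Compound 4 is estimated at 4500 nM (range 1800 nM to 11000 nM).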

Compound 4, half-maximal effective concentration: 2200 nM
Estimate against measurement, compound 4: 2.0-fold (0.31 log units) above, and the stated range covers the measured number.
By their numbers in this assay, from the lowest: compounds 2 and 4 (each within the scatter of the next); then compound 3; then compound 1.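

In this assay, methoxy in place of hydrogen on the aromatic carbon para to a large group, on the remaining benzyl, gives a 2.4-fold lower number from compound 3 to compound 4 (0.37 log units; beyond the scatter) as a modest step. This benzyl is therefore not silent once the other one already carries methoxy, and the change runs in the same direction as a 2.9-fold lower number from compound 1 to compound 3 (0.46 log units; beyond the scatter) for the whole 4-methoxyphenyl group. Nothing shown accounts for the step.

Open, going by these compounds, is whether a hydroxy, a chlorine or a dimethylamino group at this place moves the number the same way. Also open, on these data alone, is whether a carboxylic acid there would reverse the direction.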